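A few compounds are considered here, and "the series" means these few. Any claim that something is new, unique, unknown or untested is made for them only; others in the source may bear on it.

Measured so far:
- compound 1, `CC(C)(C)c1ccc(C(=O)Nc2cn3cc(-c4ccccc4)ccc3n2)cc1`, 4.83
- compound 2, `CC(C)(O)c1ccc(C(=O)Nc2cn3cc(-n4ccnc4)ccc3n2)cc1`, 1.27

In a physicochemical assay for lipophilicity, at pH 7.4 (on this read-out lower numbers stand for lower lipophilicity and higher numbers for higher lipophilicity), compound 1 gives 4.83, the higher of the two numbers; compound 2 gives 1.27, a gap beyond the scatter. Among the compounds with values here, no single-point step connects the two.

Compound 3, `CC(C)(C)c1ccc(C(=O)Nc2cn3cc(F)ccc3n2)cc1`, is not yet measured in this assay. It differs from compound 1 in one place: fluoro in place of phenyl on an aromatic carbon. A large step downward is expected, well beyond the scatter, as the change from compound 1 to compound 3 a number 1.83 log units lower from compound 1 to compound 3 (beyond the scatter). Compound 3 is estimated at 3, within 2.3 to 3.7.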

Compound 3, distribution coefficient: 3.55
Estimate against measurement, compound 3: 0.55 log units below; measured number inside the range.
By their numbers in this assay, from the lowest: compound 2; then compound 3; then compound 1.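

In this assay, within the data shown here, the change of phenyl to fluoro on an aromatic carbon gives a number 1.28 log units lower from compound 1 to compound 3 (beyond the scatter) as the first single-place step. The read-out at this position, two atoms from the ring nitrogen, therefore responds strongly to the group placed there, with the rest of compound 1 unchanged. No available measurement explains the size of this step.

From the compounds shown here alone, whether an amine or a carboxylic acid here would fall nearer compound 3 or compound 1 remains open. So does whether the step holds with another group at the far end of the amide.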